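Thiomethyl side-chain variation in a pyridylbenzylamine series

The source may hold more compounds than are shown below. What is called first, only, known or untested is meant among the compounds shown, and "the series" means these compounds.

Measured so far:
compound 1 `CC(O)CSc1nc(NCc2ccc(-c3ccccn3)cc2)c2[nH]nc(C(C)C)c2n1`: 62 nM
compound 2 `CC(C)c1n[nH]c2c(NCc3ccc(-c4ccccn4)cc3)nc(SCC(N)=O)nc12`: 192 nM
compound 3 `CCC(O)CSc1nc(NCc2ccc(-c3ccccn3)cc2)c2[nH]nc(C(C)C)c2n1`: 273 nM

All three were run in a functional assay on HT cells (Homo sapiens) for antiproliferative activity, read by fluorescence, with a stated time of 72 h; on this read-out lower numbers stand for stronger inhibition of growth and higher numbers for weaker inhibition of growth. Compound 3 gives the highest number of the three; the gap to compound 2 lies within the scatter, while the gap to compound 1 is beyond it, as a 4.4-fold higher number from compound 1 to compound 3 (0.64 log units; beyond the scatter) shows.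

Compound 4 `CC(C)c1n[nH]c2c(NCc3ccc(-c4ccccn4)cc3)nc(SCC(O)CO)nc12` has not yet been measured. It differs from compound 3 by hydroxy in place of methyl on a saturated chain carbon, two bonds along the chain from an oxygen on a saturated carbon. The step that bears most directly on it is a 4.4-fold higher number from compound 1 to compound 3 (0.64 log units; beyond the scatter), where a methyl entering at this place raised the number; here that methyl leaves and a hydroxy enters. The other step, a 3.1-fold higher number from compound 1 to compound 2 (0.49 log units; beyond the scatter), shows a polar group on the chain bound to sulfur raising the number modestly. On balance a lower number than compound 3 is expected, of about a 3.0-fold lower number from compound 3 to compound 4 (0.48 log units; beyond the scatter), landing near compound 1. Compound 4 is therefore estimated at 90 nM, with a range from 35 nM to 250 nM.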

Compound 4, concentration for 50% growth inhibition: 21 nM
Beside the measured number, compound 4's estimate is 4.3-fold (0.63 log units) above it; measured number outside the range, below it.
By their numbers in this assay, from the lowest: compound 4; then compound 1; then compounds 2 and 3 (each within the scatter of the next).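

In this assay, hydroxy and methyl on this carbon pull in opposite directions: hydroxy in place of methyl gives a 13-fold lower number from compound 3 to compound 4 (1.11 log units; beyond the scatter), and hydroxy in place of hydrogen gives a 3.0-fold lower number from compound 1 to compound 4 (0.47 log units; beyond the scatter), whereas methyl in place of hydrogen gave a 4.4-fold higher number from compound 1 to compound 3 (0.64 log units; beyond the scatter). The 1,2-dihydroxyethyl group also outdoes carbamoyl on the carbon bound to sulfur, with a 9.1-fold lower number from compound 2 to compound 4 (0.96 log units; beyond the scatter), so polar-looking replacements on this chain do not behave alike. No measurement here accounts for these steps. Going by these compounds, whether an amine or a carboxylic acid in place of this hydroxy would keep the low number remains open. So does the effect of a longer chain carrying both hydroxy groups.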